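The source may hold more compounds than are shown below. What is called first, only, known or untested is meant among the compounds shown, and "the series" means these compounds.

Measured so far in a functional assay on a cell-free system (plasma) for agonist activity at thromboxane A2 receptor (Homo sapiens); a lower number here means a stronger inhibitor, a higher number a weaker inhibitor:
compound 1 `O=C(O)CCC/C=C1/C[C@H]2C[C@@H](O)[C@H](/C=N/NC(=O)Nc3ccc([N+](=O)[O-])cc3)[C@H]2C1`: 50 nM
compound 2 `O=C(O)CC/C=C1\C[C@H]2C[C@@H](O)[C@H](/C=N/NC(=O)Nc3cccc(Cl)c3)[C@H]2C1`: 5200 nM
compound 3 `O=C(O)CCC/C=C1/C[C@H]2C[C@@H](O)[C@H](/C=N/NC(=O)Nc3ccccc3)[C@H]2C1`: 100 nM

Compound 2 stands highest of the three in this assay; compound 3 gives 100 nM and compound 1 gives 50 nM, both lower beyond the scatter. Compound 4 `O=C(O)CC/C=C1/C[C@H]2C[C@@H](O)[C@H](/C=N/NC(=O)Nc3cccc(Cl)c3)[C@H]2C1` keeps every atom and bond of compound 2 and differs only in configuration: the two compounds have the same atoms and bonds and differ only in configuration as drawn: 1 of 6 stereo elements differ; a double bond is drawn E in compound 2 and Z in compound 4. Among the compounds with values here, the single measured step, a 2.0-fold higher number from compound 1 to compound 3 (0.30 log units; within the scatter), concerns the aromatic substituent and lies within the scatter, so it does not bear on a change of double-bond geometry. Within the data shown here, no measured pair isolates that geometry: compounds 1 and 3 share the geometry drawn for compound 4, but they also differ from compound 2 in chain length and aryl substituent. The step is therefore estimated with wide uncertainty, expected toward lower numbers: a 3.5-fold lower number from compound 2 to compound 4 (0.54 log units; beyond the scatter). Compound 4 is estimated at 1500 nM (range 250 nM to 9000 nM).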

Compound 4, half-maximal inhibitory concentration: 600 nM
Estimate against measurement, compound 4: 2.5-fold (0.40 log units) above; low and high end bracket the measured number.
By their numbers in this assay, from the lowest: compounds 1 and 3 (each within the scatter of the next); then compound 4; then compound 2.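

In this assay, double-bond geometry alone now has a measured effect, with an 8.7-fold lower number from compound 2 to compound 4 (0.94 log units; beyond the scatter). The earlier step concerned only the aromatic substituent, so it left this double bond unresolved. This step can be assigned to that single stereo element, with no other structural change in the pair: the fact that compounds 2 and 4 differ only in the configuration as drawn.

From the compounds shown here alone, whether the geometry step carries over to the chain and aryl substituents of compound 1 and compound 3 remains open. Going by these compounds, what a tetrazole in place of the carboxylic acid would give in either geometry also remains open.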